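Swapping a Catechol for a Fused Bicyclic Group

The source may hold more compounds than are shown below. What is called first, only, known or untested is meant among the compounds shown, and "the series" means these compounds.

Measured so far:
compound 1 `CCOC(=O)C1=C(Nc2ccccc2)S/C(=C\c2ccc(O)c(O)c2)C1=O` – 48.7%
compound 2 `CCOC(=O)C1=C(Nc2ccccc2)S/C(=C\c2ccc(C(=O)OCC)[nH]2)C1=O` – 60.1%

Both compounds were tested in a functional assay on JAR cells (Homo sapiens) for inhibition, read by MTT assay, with a stated time of 72 h, tested at 10 uM; a lower number here means less inhibition, a higher number more inhibition at the concentration tested (going by the name of the read-out). Compound 1 gives 48.7%, the lowest of the two numbers. Compound 2 gives 60.1%, a number higher than that of compound 1 by more than the usual scatter of repeated measurements.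

Compound 3 `CCOC(=O)C1=C(Nc2ccccc2)S/C(=C\c2cc3cccnc3[nH]2)C1=O` has not yet been measured. Relative to compound 1 it differs in one place: a group of 9 heavy atoms (7 carbon, 2 nitrogen; one five-membered aromatic ring with 1 hetero atom, one six-membered aromatic ring with 1 hetero atom) in place of a group of 8 heavy atoms (6 carbon, 2 oxygen; one six-membered aromatic ring of carbon only), on a double-bonded chain carbon bound to a double-bonded ring carbon. Among the measured compounds shown here, no pair of measured compounds differs in exactly one place, so no measured step can be compared directly with this change. For the measured compounds named here, the only guide is that compound 2, which also lacks the 3,4-dihydroxyphenyl, gives 60.1% in this assay, whereas compound 1 gives 48.7%.

For compound 3 the expected step is a number 4.3 percentage points higher from compound 1 to compound 3 (within the scatter), a small rise that may well stay within the scatter. Compound 3 is therefore estimated at 53%, with a range from 30% to 74%.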

Compound 3, a percentage reported as inhibition, at one concentration (the size of the read-out at that concentration, not a potency): 54.3%
For compound 3 the middle estimate is 1.3 percentage points below the measured one; measured number inside the range.
By their numbers in this assay, from the lowest: compounds 1, 3 and 2 (each within the scatter of the next, the first and the last beyond it).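

In this assay, among the compounds shown here, the first step that can be read at this position, on a double-bonded chain carbon bound to a double-bonded ring carbon, is a number 5.6 percentage points higher from compound 1 to compound 3 (within the scatter). The 3,4-dihydroxyphenyl can therefore give way to a group of one five-membered and one six-membered aromatic ring, each with 1 hetero atom, without a shift that stands clear of the usual scatter of repeated measurements, so in this one pair neither the 2 oxygen atoms nor the carbon-only ring proves necessary for this level of inhibition. No measured information on the properties of these two groups accompanies the result, so this pair says nothing about why the numbers stay so close.

Still open, from the compounds shown here alone, is whether a simpler group at this position, such as an unsubstituted phenyl or a phenyl with a single hydroxyl, would behave in the same way, and which of the two oxygen atoms, if either, matters. Also open, going by these compounds, is what a carboxylic acid in place of the ethyl ester of the shared core would do, and how these compounds compare across a range of concentrations.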